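Notes on an arylidene series: fluoro for tert-butyl

This account rests on a few compounds, and the source may have more. Where it says the series, first, only, none or still open, it means among the compounds named here.

Compound 1 `COc1ccc(/C=C2/CN(C)/C(=N/c3ccc(C)cc3)S2)cc1` in a functional assay on HCT-116 cells (Homo sapiens) for antiproliferative activity, read by MTT assay, with a stated time of 72 h (on this read-out higher numbers stand for weaker inhibition and lower numbers for stronger inhibition), gives 11100 nM. Compound 2 `COc1ccc(/C=C2\S/C(=N\c3ccc(C(C)(C)C)cc3)N(C)C2=O)cc1` in this assay gives only a limit, > 100000 nM, and not a number, which is the limit of > 100000 nM in this assay, at which 1 of the 2 values shown sits. Compound 2 therefore stands at the weak end of the numbers shown. Compound 3 `COc1ccc(/C=C2\S/C(=N\c3ccc(F)cc3)N(C)C2=O)cc1` differs from compound 2 by fluoro in place of tert-butyl on an aromatic carbon. Going by the values given here, no measured step covers such a change, so its size is open; a move toward stronger inhibition is plausible but not assured. Compound 3 is expected to give about 60000 nM, within 15000 nM to 200000 nM. That estimate is expected to correspond to an at least 1.6-fold lower number from compound 2 to compound 3 (0.22 log units; that floor lies within the scatter), with a fair chance that only a limit is again reported.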

Compound 3, half-maximal inhibitory concentration: 13300 nM
Beside the measured number, compound 3's estimate is 4.5-fold (0.65 log units) above it; measured number outside the range, below it.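

Exchanging tert-butyl for fluoro on this aromatic carbon moves the series from a limit to a measured number in this assay, with an at least 7.5-fold lower number from compound 2 to compound 3 (0.87 log units; beyond the scatter). The entry for compound 2, > 100000 nM, is a limit and not a number. The step is therefore only a floor, because its starting point is a limit: the limit of > 100000 nM in this assay, at which 1 of the 3 values shown sits.

With only tert-butyl and fluoro shown on this aromatic carbon, the read-out for hydrogen, chloro, methoxy or an amine there remains open. Also open, from the compounds shown here alone, is how far the true size of this step exceeds its floor.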